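The source may hold more compounds than are shown below. What is called first, only, known or untested is meant among the compounds shown, and "the series" means these compounds.

In a functional assay with Alpha-1A adrenergic receptor (Homo sapiens) as the target, read by calcium flux (on this read-out lower numbers stand for smaller maximal responses and higher numbers for larger maximal responses), compound 2 `Cn1ccnc1-c1ccccc1NCC1=NCCN1` gives 88%. Compound 1 `Cn1ncnc1-c1ccccc1NCC1=NCCN1` gives 91% in this assay, and the step of a number 3 percentage points lower from compound 1 to compound 2 (within the scatter) is within the scatter, so the two compounds stand together rather than apart. Compound 3 `Cn1nccc1-c1ccccc1NCC1=NCCN1` has not yet been measured; it differs from compound 2 by 1-methyl-1H-pyrazol-5-yl in place of 1-methyl-1H-imidazol-2-yl on an aromatic carbon. Within the data shown here, the one measured step also replaced one five-membered aromatic ring with another and stayed within the scatter, so the expected step of no change at the digits printed from compound 2 to compound 3 (within the scatter) is none beyond the scatter. Compound 3 is therefore estimated at 88%, with a range from 75% to 100%.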

Compound 3, largest response reached (reported as maximal response), in percent of the reference or control that the assay uses: 108%
For compound 3 the middle estimate is 20 percentage points below the measured one, and the stated range ends below it.
By their numbers in this assay, from the lowest: compounds 2 and 1 (each within the scatter of the next); then compound 3.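

Within the family of five-membered aromatic rings, this position on an aromatic carbon is not indifferent to the choice of ring: this assay shows a number 20 percentage points higher from compound 2 to compound 3 (beyond the scatter) and also a number 17 percentage points higher from compound 1 to compound 3 (beyond the scatter). Compound 2 and compound 3 have the same atoms, joined differently, so rearranging the ring alone is enough to change the maximal response. No measurement shown here explains this change.

What the compounds leave open is whether a phenyl or thiophene ring at this place would give a similar response. An ethyl group in place of the ring's methyl is equally untested by these results.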